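A few compounds are considered here, and "the series" means these few. Any claim that something is new, unique, unknown or untested is made for them only; others in the source may bear on it.

Measured in a functional assay on RAW264.7 cells (Mus musculus) for inhibition; on this read-out lower numbers stand for stronger inhibition and higher numbers for weaker inhibition:
Compound 1 `CCOC(=O)C1=CCCCC1S(=O)(=O)Nc1ccc(Cl)cc1F`: 160 nM
Compound 2 `CCOC(=O)C1=CCCCC1S(=O)(=O)Nc1ccccc1F`: 75 nM
Compound 3 `CCOC(=O)C1=CCCCC1S(=O)(=O)Nc1ccc(F)cc1F`: 16 nM

Compound 1 has the highest number of the three, making it the weakest inhibitor so far. Compound 4 `CCOC(=O)C1=CCCCC1S(=O)(=O)N(C)c1ccc(Cl)cc1F` changes it by putting methyl in place of hydrogen on a sulfonamide nitrogen. Among the measured compounds shown here, no measured step touches this nitrogen. For the measured compounds named here, the only guides are modest changes on the aromatic ring: a 2.1-fold lower number from compound 1 to compound 2 (0.33 log units; beyond the scatter), a 10-fold lower number from compound 1 to compound 3 (1.00 log units; beyond the scatter) and a 4.7-fold lower number from compound 2 to compound 3 (0.67 log units; beyond the scatter). All three measured compounds keep the hydrogen that compound 4 loses, so the data give no direct size for this change. A weaker result, with a higher number in this assay, is expected, though with wide uncertainty. The estimate implies a 9.4-fold higher number from compound 1 to compound 4 (0.97 log units; beyond the scatter). Compound 4 is estimated at 1500 nM, with an expected range from 200 nM to 10000 nM.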

Compound 4, half-maximal inhibitory concentration: 230 nM
For compound 4 the middle estimate is 6.5-fold (0.81 log units) above the measured one; the range from low to high includes it.
By their numbers in this assay, from the lowest: compound 3; then compound 2; then compounds 1 and 4 (each within the scatter of the next).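

In this assay, methyl in place of hydrogen on the sulfonamide nitrogen gives (a 1.4-fold higher number from compound 1 to compound 4 (0.16 log units; within the scatter)), so compound 1 and compound 4 cannot be told apart. On this core, inhibition therefore does not depend on keeping the hydrogen on this nitrogen, at least when methyl replaces it. Nothing available explains why this change is tolerated. From the compounds shown here alone, whether an ethyl group, a longer chain or an acetyl group on this nitrogen would also be tolerated remains open. Going by these compounds, it is also open whether methyl would have the same effect on compound 3, the strongest inhibitor here.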